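The source may report more compounds than this note shows. Statements on the series, on what has been measured and on what is new or still open speak of the compounds shown alone.

Measured compounds:
- compound 1, `NC(=O)CC[C@H](NC(=O)CN(c1ncnc2c1ncn2C1CCCCO1)C1CC1)C(=O)OCc1ccccc1`: 39.4%
- compound 2, `CC(C)(C)OC(=O)NCCCC[C@H](NC(=O)CN(c1ncnc2c1ncn2C1CCCCO1)C1CC1)C(=O)OCc1ccccc1`: 32.7%

Both were tested in a functional assay on the whole organism (Tail, strain ICR) with Mus musculus as the target, in the tail flick test, with a stated time of 60 min, at a dose of 25 umol/kg by the oral route; on this read-out higher numbers stand for a stronger effect at the one dose given and lower numbers for a weaker effect. For the measured compounds named here, of the two numbers, compound 2 holds the lower one, but the only measured step, a number 6.7 percentage points lower from compound 1 to compound 2 (within the scatter), is within the scatter, so the two compounds cannot be told apart on this read-out.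

Compound 3, `N=C(N)NCCC[C@H](NC(=O)CN(c1ncnc2c1ncn2C1CCCCO1)C1CC1)C(=O)OCc1ccccc1`, has not yet been measured. It differs from compound 2 by a group of 4 heavy atoms (1 carbon, 3 nitrogen; no ring) in place of a group of 9 heavy atoms (6 carbon, 1 nitrogen, 2 oxygen; no ring), on a saturated chain carbon, four bonds along the chain from an amide-type nitrogen and a carbonyl carbon. Going by the values given here, no measured pair shows this kind of exchange: the one step available, from compound 1 to compound 2, exchanged a different group at a different place and stayed within the scatter. Among the compounds with values here, it therefore gives no direct guide to the present step, only the observation that the two compounds measured so far are of similar size in this assay.

With nothing in the data pointing in either direction, no step beyond the scatter is expected here, though the uncertainty is wide. The expected step is a number 0.7 percentage points lower from compound 2 to compound 3 (within the scatter). Compound 3 is accordingly estimated at 32%, within a range from 10% to 55%.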

Compound 3, a percentage reported as activity, at one dose (the size of the read-out at that dose, not a potency): 52.4%
Beside the measured number, compound 3's estimate is 20.4 percentage points below it, and the stated range covers the measured number.
By their numbers in this assay, from the lowest: compounds 2 and 1 (each within the scatter of the next); then compound 3.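

In this assay, the first two compounds could not be told apart, so the side chain on this saturated carbon had not yet been shown to matter for the read-out. The group of 4 heavy atoms (1 carbon, 3 nitrogen; no ring) now separates compound 3 from both: replacing the ((tert-butoxycarbonyl)amino)methyl group with it gives a number 19.7 percentage points higher from compound 2 to compound 3 (beyond the scatter), and the comparison with the carbamoyl side chain gives a number 13 percentage points higher from compound 1 to compound 3 (beyond the scatter), both modest steps that leave compound 3 with the highest number of the three. No accompanying evidence bears on what lies behind these steps.

The compounds shown leave open whether a primary amine or a carboxylic acid on this chain would give a number like that of compound 3, and whether a longer chain ending in the same group would keep it. Going by these compounds, they also rest on a single dose and a single time, so how the read-out changes with dose remains open.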